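The compounds below may be only part of what the source reports. "The series", "measured", "known", "first", "only" and "open" are said of these compounds alone.

Measured so far, in a toxicity assay on MCF-10A cells (Homo sapiens) for cytotoxicity, read by MTT assay, with a stated time of 48 h; on this read-out higher numbers stand for weaker inhibition and lower numbers for stronger inhibition:
compound 1 `Cn1cccc1C(=O)/C=C/c1ccc2c(c1)B(O)OC2` gives > 100000 nM, which is a limit of the assay rather than a number.
compound 2 `Cc1cccc(C(=O)/C=C/c2ccc3c(c2)B(O)OC3)c1` gives 15900 nM.

Compound 2 therefore holds the only actual number among the two results shown; the other result is a limit. Among the compounds with values here, the one measured step, an at least 6.2-fold lower number from compound 1 to compound 2 (0.79 log units; beyond the scatter), is known only as a lower bound because compound 1 sits at the limit of > 100000 nM in this assay, at which 1 of the 2 values shown sits. That step exchanges the whole group attached to the carbonyl carbon and says nothing directly about altering a substituent on the 3-methylphenyl ring.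

Compound 3 `Nc1cccc(C(=O)/C=C/c2ccc3c(c2)B(O)OC3)c1` is the compound still to be measured, and it differs from compound 2 by amino in place of methyl on an aromatic carbon. Within the data shown here, no measured step in this small set involves a change of this kind, so there is nothing of the same sort to lean on. Without such a guide, the expected step is a 1.3-fold higher number from compound 2 to compound 3 (0.10 log units; within the scatter), within the usual scatter of this assay in either direction, and the uncertainty is correspondingly wide. Compound 3 is therefore estimated at 20000 nM in this assay, with a range from 6000 nM to 70000 nM.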

Compound 3, half-maximal inhibitory concentration: 19600 nM
Compound 3: the middle estimate sits 1.0-fold (0.01 log units) above what was measured; measured number inside the range.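

In this assay, amino in place of methyl on an aromatic carbon, meta to a large group, gives a 1.2-fold higher number from compound 2 to compound 3 (0.09 log units; within the scatter), so the two groups cannot be told apart at this position. The earlier step exchanged the whole group on the carbonyl carbon, whereas this one alters a single substituent on the ring: amino brings a hydrogen-bond donor and a hydrogen-bond acceptor that methyl lacks, with no difference beyond the scatter in this cell read-out. Replacing 1-methyl-1H-pyrrol-2-yl with 3-aminophenyl gives an at least 5.1-fold lower number from compound 1 to compound 3 (0.70 log units; beyond the scatter), which places 3-aminophenyl on the same side of that comparison as 3-methylphenyl, though the size is only a lower bound because compound 1 sits at a limit of the assay: the limit of > 100000 nM in this assay, at which 1 of the 3 values shown sits.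

The compounds shown leave open whether a hydroxyl, a methoxy group or a carboxylic acid at this same place would also stay within the scatter of compound 2. They also leave open whether amino or methyl would read the same at another place on the ring, since this pair tests only one position.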